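The compounds below may be only part of what the source reports. "The series", "measured", "known", "first", "only" and "open" are said of these compounds alone.

Of the compounds shown here, three sharing one core have been measured in a functional assay on A549 cells (Homo sapiens) for cytotoxicity, read by MTT assay, with a stated time of 72 h; a higher number here means a weaker inhibitor, a lower number a stronger inhibitor. Compound 1 `O=C(N/N=C/c1ccc([N+](=O)[O-])cc1)Nc1cc2c(Nc3ccc(F)c(Cl)c3)ncnc2cc1O[C@H]1CCOC1` gives 31200 nM, compound 2 `COc1ccc(/C=N/NC(=O)Nc2cc3c(Nc4ccc(F)c(Cl)c4)ncnc3cc2O[C@H]2CCOC2)cc1` gives 33100 nM, and compound 3 `CC(C)(C)c1cc(/C=N/NC(=O)Nc2cc3c(Nc4ccc(F)c(Cl)c4)ncnc3cc2O[C@H]2CCOC2)cc(C(C)(C)C)c1O` gives 19000 nM. Compound 2 therefore stands within the scatter of both other compounds, and these numbers offer no clear ranking.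

The next compound is compound 4 `O=C(N/N=C/c1ccc(O)cc1)Nc1cc2c(Nc3ccc(F)c(Cl)c3)ncnc2cc1O[C@H]1CCOC1`. It differs from compound 2 by hydrogen in place of methyl on an oxygen on an aromatic ring, which is hydrogen in place of methyl on an oxygen on an aromatic ring, so that methoxy becomes hydroxy. For the measured compounds named here, one measured step bears directly on this part of the molecule: a 1.1-fold higher number from compound 1 to compound 2 (0.03 log units; within the scatter), with methoxy in place of nitro on an aromatic carbon. That step lies within the scatter. Compound 3 also carries a hydroxy on an aromatic ring, together with two tert-butyl groups, and its 19000 nM remains within the scatter of compound 2. Going by the values given here, no measured pair isolates the loss of this methyl, so the evidence is indirect.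

On this basis, no change beyond the scatter is expected in this assay. The estimated change is a 1.2-fold lower number from compound 2 to compound 4 (0.07 log units; within the scatter). In this assay the estimate for compound 4 is 28000 nM, with an expected range from 14000 nM to 55000 nM.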

Compound 4, half-maximal inhibitory concentration: 1320 nM
The estimate for compound 4 lay 21-fold (1.33 log units) above the measured number, and the stated range ends above it.
By their numbers in this assay, from the lowest: compound 4; then compounds 3, 1 and 2 (each within the scatter of the next).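

In this assay, for the compounds shown here, this position proves far more sensitive than the earlier compounds suggested: the exchange of nitro for methoxy gave only a 1.1-fold higher number from compound 1 to compound 2 (0.03 log units; within the scatter) and so offered no sign that the group here matters. Removing the methyl from the oxygen on the aromatic ring gives a 25-fold lower number from compound 2 to compound 4 (1.40 log units; beyond the scatter) and hydroxy in place of nitro gives a 24-fold lower number from compound 1 to compound 4 (1.37 log units; beyond the scatter) so the 4-hydroxyphenyl group of compound 4 stands apart from both the 4-methoxyphenyl group and its nitro counterpart, and the loss of a single carbon is enough to produce the large step. Nothing in the data explains why the hydroxy compound separates so sharply from the other two.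

Compound 3 also carries a hydroxy on its aromatic ring, together with two tert-butyl groups, and gives 19000 nM but no step shown isolates the effect of those tert-butyl groups on the hydroxy. The compounds shown also leave open whether an amine, a carboxylic acid or an ethoxy group at this place would behave like the hydroxy of compound 4 or like the methoxy of compound 2.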